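The compounds below may be only part of what the source reports. "The series", "measured", "known", "first", "only" and "open" are said of these compounds alone.

Compound 2 `C=CCN1C(=O)C(O)=C(C(=O)c2ccc(C)nc2)C1c1ccc(C(F)(F)F)cc1` was tested in an assay on isolated protein for inhibition of annexin A2/S100-A10 (Homo sapiens), with a stated time of 5 min, tested at 50 uM (on this read-out lower numbers stand for less inhibition and higher numbers for more inhibition at the one concentration tested (going by the name of the read-out)), and gives 102%. Compound 1 `CCCc1ccc(C2C(C(=O)c3ccc(C)cc3)=C(O)C(=O)N2CC(C)O)cc1` gives 97% in this assay; the two numbers lie within the usual scatter of one another, so compound 2 stands alongside compound 1 rather than apart from it. Compound 3 `C=CCN1C(=O)C(O)=C(C(=O)c2ccc(Cl)cc2)C1c1ccc(C(F)(F)F)cc1` has not yet been measured. It differs from compound 2 in one place: 4-chlorophenyl in place of 6-methylpyridin-3-yl on a carbonyl carbon. Among the compounds with values here, no step between two measured compounds shows what this change does. Compound 3 is expected to stay near where compound 2 stands, with a step of a number 5 percentage points lower from compound 2 to compound 3 (within the scatter), which is none beyond the scatter. The estimate for compound 3 is 97%, within 82% to 106%.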

Compound 3, a percentage reported as inhibition, at one concentration (the size of the read-out at that concentration, not a potency): 120%
For compound 3 the middle estimate is 23 percentage points below the measured one; the whole stated range lies below it.
By their numbers in this assay, from the lowest: compounds 1 and 2 (each within the scatter of the next); then compound 3.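

In this assay, 4-chlorophenyl in place of 6-methylpyridin-3-yl on a carbonyl carbon gives a number 18 percentage points higher from compound 2 to compound 3 (beyond the scatter), a modest step. Within the data shown here, this shows that the aromatic group at this position can move the read-out, which the earlier compounds could not show. The change removes the ring nitrogen and the methyl and adds the chlorine in a single step, and no measurement here accounts for the result.

Which of these parts matters remains open. So does how 4-bromophenyl, 4-methoxyphenyl or an unsubstituted phenyl would read at this position.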